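Bromo to Nitro on a Sulfanyl Phenyl Ring

The source may report more compounds than this note shows. Statements on the series, on what has been measured and on what is new or still open speak of the compounds shown alone.

Of the compounds shown here, three have so far been tested in a functional assay on SGC-7901 cells (Homo sapiens) for cytotoxicity, read by MTT assay, with a stated time of 48 h; on this read-out lower numbers stand for stronger inhibition and higher numbers for weaker inhibition. Compound 1 `O=C(CSc1ncccn1)N1N=C(c2cc3ccccc3oc2=O)C[C@@H]1c1ccc(C(F)(F)F)cc1` gives 4390 nM. Compound 2 `CC1=NN(C(=O)CSc2ccccc2)[C@@H](c2cc(Br)cc(Br)c2O)C1` gives 24100 nM. Compound 3 `O=C(CSc1ccc(Br)cc1)N1N=C(c2cc3ccccc3oc2=O)C[C@@H]1c1ccc(C(F)(F)F)cc1` gives 12100 nM. Among the measured compounds shown here, of the three numbers, that of compound 3 is the second highest; compound 2 stands within the scatter of compound 3, and the only step beyond the scatter is a 2.8-fold higher number from compound 1 to compound 3 (0.44 log units; beyond the scatter), where 4-bromophenyl took the place of pyrimidin-2-yl on a sulfur.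

Compound 4 `O=C(CSc1ccc([N+](=O)[O-])cc1)N1N=C(c2cc3ccccc3oc2=O)C[C@@H]1c1ccc(C(F)(F)F)cc1` differs from compound 3 in one place: nitro in place of bromo on an aromatic carbon.

For the measured compounds named here, no measured pair shows this exchange. Going by the values given here, the single step that touches the group on the sulfur, a 2.8-fold higher number from compound 1 to compound 3 (0.44 log units; beyond the scatter), concerns a different replacement and gives no reading on a nitro against a bromo. The data therefore offer no ground for a direction, and the expected step from compound 3 to compound 4 in this assay is one that stays within the scatter, namely a 1.2-fold lower number from compound 3 to compound 4 (0.08 log units; within the scatter). On that basis compound 4 is estimated at 10000 nM in this assay. The expected range for compound 4 runs from 4000 nM to 30000 nM.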

Compound 4, half-maximal inhibitory concentration: 8510 nM
Compound 4: the middle estimate sits 1.2-fold (0.07 log units) above what was measured, and the stated range covers the measured number.
By their numbers in this assay, from the lowest: compounds 1, 4, 3 and 2 (each within the scatter of the next, the first and the last beyond it).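

In this assay, the first exchange read on this aromatic carbon, para to a large group, gives a 1.4-fold lower number from compound 3 to compound 4 (0.15 log units; within the scatter) and so does not separate nitro from bromo at this position. The 4-nitrophenyl group also stands close to pyrimidin-2-yl on the sulfur, with a 1.9-fold higher number from compound 1 to compound 4 (0.29 log units; within the scatter), whereas the earlier step of a 2.8-fold higher number from compound 1 to compound 3 (0.44 log units; beyond the scatter) had set 4-bromophenyl apart from pyrimidin-2-yl; compound 4 thus lies within the scatter of both compounds, and that earlier gap does not extend to every phenyl ring carrying a group at this place. Nothing available explains these readings or says what the small difference between bromo and nitro reflects.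

The compounds shown leave open how an amine, a carboxylic acid or a methoxy group on the same aromatic carbon would read, and whether a bare phenyl ring on the sulfur would stay within this range on the shared core. They also leave open whether a longer chain in place of the methylene that links the sulfur to the carbonyl would keep these numbers.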